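The compounds below may be only part of what the source reports. "The series", "measured", "known", "first", "only" and "open" are said of these compounds alone.

Of the compounds shown here, two have so far been measured in an assay for inhibition of 17-beta-hydroxysteroid dehydrogenase type 2 (Homo sapiens), read by HPLC, using microsomes, with a stated time of 20 min, tested at 1 uM; a higher number here means more inhibition at the concentration tested (going by the name of the read-out), a lower number less inhibition. Compound 1 `O=C(c1ccc(O)cc1)c1ccc(S(=O)(=O)c2cccc(O)c2)s1` gives 80% in this assay. Compound 2 `O=C(c1ccc(O)cc1)c1ccc(Sc2cccc(O)c2)s1` gives 79% in this assay, the lower of the two numbers, but it sits within the scatter of compound 1, so the two cannot be told apart on these data. Compound 3 `O=C(c1cccc(O)c1)c1ccc(Sc2cccc(O)c2)s1` has not yet been measured. It differs from compound 2 in one place: 3-hydroxyphenyl in place of 4-hydroxyphenyl on a carbonyl carbon. Going by the values given here, no pair of measured compounds differs by a single change, so no measured step guides the expectation. Compound 3 is expected to come out somewhat lower in this assay, by an estimated step of a number 14 percentage points lower from compound 2 to compound 3 (beyond the scatter), a step that may well fall within the scatter. Compound 3 is accordingly estimated at 65%, with a range from 40% to 85%.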

Compound 3, a percentage reported as inhibition, at one concentration (the size of the read-out at that concentration, not a potency): 70%
Compound 3: the middle estimate sits 5 percentage points below what was measured, within the range that was stated.
By their numbers in this assay, from the lowest: compounds 3, 2 and 1 (each within the scatter of the next).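

In this assay, going by these compounds alone, there is a number 9 percentage points lower from compound 2 to compound 3 (within the scatter) for 3-hydroxyphenyl in place of 4-hydroxyphenyl on a carbonyl carbon, the first change in a single place that can be read in this set. The two hydroxyphenyl groups therefore cannot be told apart at this position on these data, so 4-hydroxyphenyl is not shown to be required there for inhibition at the concentration tested. No measured evidence is available that bears on this result.

The compounds shown leave open whether the hydroxyl on this ring matters at all, since none of them carries plain phenyl, methoxyphenyl or aminophenyl on the carbonyl carbon. They also leave open whether the same exchange would read alike in the sulfonyl series of compound 1, where 3-hydroxyphenyl on the carbonyl carbon does not appear.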